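Notes on aryl variation at the core in cytotoxicity

The source may hold more compounds than are shown below. What is called first, only, known or untested is meant among the compounds shown, and "the series" means these compounds.

Measured compounds:
- compound 1 `Cc1cc(-c2ccsc2)cn2c(CSCCc3ccccc3)cnc12`: >= 4 ug/mL in an ADME assay on HEL cells (Homo sapiens) for cytotoxicity, with a stated time of 3 days; on this read-out higher numbers stand for lower toxicity in this test and lower numbers for higher toxicity in this test
- compound 2 `Cc1cc(I)c2ncc(CSCCc3ccccc3)n2c1`: >= 4 ug/mL in this assay
- compound 3 `Cc1cc(-c2cccs2)c2ncc(CSCCc3ccccc3)n2c1`: 100 ug/mL in this assay

In this assay compound 1 gives only a limit, >= 4 ug/mL, not a number. Compound 2 likewise gives only a limit, >= 4 ug/mL. Compound 3 gives a number, 100 ug/mL. Among the compounds with values here, the one step between measured compounds, a step that the limit leaves unreadable from compound 2 to compound 3, is not readable in size because the limit of >= 4 ug/mL in this assay, at which 2 of the 3 values shown sit, hides it. Where compound 1 stands is therefore known only as a limit, and two of three values sit at that same limit.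

Compound 4 `Cc1cc(-c2cccc(O)c2)cn2c(CSCCc3ccccc3)cnc12` differs from compound 1 by 3-hydroxyphenyl in place of thiophen-3-yl on an aromatic carbon. No measured step touches this change, and the only step shown is unreadable, so no direction can be taken from it. The expected step in this assay, a step that the limit leaves unreadable from compound 1 to compound 4, is set wide. Compound 4 is estimated at 30 ug/mL, with a range from 4 ug/mL to 100 ug/mL, and a sizable chance that only a limit is reported.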

Compound 4, minimum cytotoxic concentration: 20 ug/mL
Compound 4: the middle estimate sits 1.5-fold (0.18 log units) above what was measured; measured number inside the range.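

No new step can be read between compound 1 and compound 4, because compound 1 carries only a limit: the limit of >= 4 ug/mL in this assay, at which 2 of the 4 values shown sit.

The compounds shown leave open in which direction, and how far, 3-hydroxyphenyl in place of thiophen-3-yl on the shared core moves the read-out in this assay.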